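A few compounds are considered here, and "the series" means these few. Any claim that something is new, unique, unknown or untested is made for them only; others in the source may bear on it.

In a functional assay on A-375 cells (Homo sapiens) for cytotoxicity, read by MTT assay (a higher number here means a weaker inhibitor, a lower number a stronger inhibitor), two compounds of a shared core have been measured. Compound 1 `O=S(=O)(NCCNc1nccc(-c2c(-c3cccc(F)c3)nc3sccn23)n1)c1ccc(F)cc1` gives 9450 nM. Compound 2 `O=S(=O)(NCCCNc1nccc(-c2c(-c3cccc(F)c3)nc3sccn23)n1)c1ccc(C(F)(F)F)cc1` gives 4090 nM, the lowest of the two numbers; the number for compound 1 is higher, and the gap between them lies beyond the usual scatter of this assay. The two compounds differ in more than one place, so nothing in the data ties that gap to any single feature.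

Compound 3 `O=S(=O)(NCCCNc1nccc(-c2c(-c3cccc(F)c3)nc3sccn23)n1)c1ccc(Cl)cc1` departs from compound 2 by chloro in place of trifluoromethyl on an aromatic carbon. Both the leaving and the entering group carry no hydrogen-bond donor or acceptor, and the rest of the molecule is unchanged. Going by the values given here, nothing measured so far isolates the effect of the group on the aromatic carbon para to the large group, so the expected step from compound 2 to compound 3, a 1.2-fold higher number from compound 2 to compound 3 (0.09 log units; within the scatter), is taken to be small and is estimated to fall within the scatter, with no confident direction. Compound 3 is therefore expected to give about 5000 nM, within a range from 2000 nM to 12000 nM.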

Compound 3, half-maximal inhibitory concentration: 5900 nM
Beside the measured number, compound 3's estimate is 1.2-fold (0.07 log units) below it; measured number inside the range.
By their numbers in this assay, from the lowest: compounds 2, 3 and 1 (each within the scatter of the next, the first and the last beyond it).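

In this assay, going by these compounds alone, the exchange on the aromatic carbon para to a large group gives the first reading of this position alone: a 1.4-fold higher number from compound 2 to compound 3 (0.16 log units; within the scatter) shows that 4-(trifluoromethyl)phenyl and 4-chlorophenyl are not told apart here. The step of a 1.6-fold lower number from compound 1 to compound 3 (0.20 log units; within the scatter) also stays within the scatter, but the exchanged piece takes in the chain as well as the halogen, so it cannot be tied to either one. Nothing available explains these numbers.

The compounds shown leave open how an amine or a carboxylic acid on that aromatic carbon would read, since neither group compared there carries a hydrogen-bond donor or acceptor. Within the data shown here, they also hold no pair differing in the chain alone, so the gap between compound 1 and compound 2 remains unassigned.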